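From 4-bromophenyl to 3-cyanophenyl on a shared core

A few compounds are considered here, and "the series" means these few. Any claim that something is new, unique, unknown or untested is made for them only; others in the source may bear on it.

Of the compounds shown here, three on a shared core have been measured in a functional assay (muscle tissue) with Cavia porcellus as the target; a lower number here means that less compound is needed, a higher number that more compound is needed for the effect. Compound 1 `COC(=O)C1=C(C)N=C(C)/C(=C(\O)OC)C1c1cccc(C)c1` gives 110 nM, compound 2 `COC(=O)C1=C(C)N=C(C)/C(=C(\O)OC)C1c1cccc(OC(C)=O)c1` gives 6030 nM, and compound 3 `COC(=O)C1=C(C)N=C(C)/C(=C(\O)OC)C1c1ccc(Br)cc1` gives 540 nM. Compound 3 therefore has the second highest of the three numbers.

Compound 4 `COC(=O)C1=C(C)N=C(C)/C(=C(\O)OC)C1c1cccc(C#N)c1` differs from compound 3 at one place, a saturated ring carbon: 3-cyanophenyl in place of 4-bromophenyl on a saturated ring carbon.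

Among the measured compounds shown here, two measured steps bear on this change. The exchange that arrives at 4-bromophenyl on the same carbon gave a 4.9-fold higher number from compound 1 to compound 3 (0.69 log units; beyond the scatter), a modest step that ends at compound 3. Acetoxy in place of methyl on an aromatic carbon gave a 55-fold higher number from compound 1 to compound 2 (1.74 log units; beyond the scatter), a large step showing how far a change on that aromatic ring can move the number. For the measured compounds named here, no measured compound carries a nitrile, so neither step gives a direct reading.

Leaving 4-bromophenyl may recover part of the modest step, so a modest move to a lower number is expected in this assay, although the result for compound 2 argues for caution. The expected move is a 2.2-fold lower number from compound 3 to compound 4 (0.33 log units; beyond the scatter). For compound 4 the estimated value is 250 nM, with an expected range of 60 nM to 1200 nM.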

Compound 4, half-maximal effective concentration: 34.7 nM
For compound 4 the middle estimate is 7.2-fold (0.86 log units) above the measured one; the measured number lies below the stated range.
By their numbers in this assay, from the lowest: compound 4; then compound 1; then compound 3; then compound 2.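

In this assay, the step of a 16-fold lower number from compound 3 to compound 4 (1.19 log units; beyond the scatter) is far larger than the step that led to compound 3, and it gives the lowest number of the four compounds. The change of aryl group at this saturated ring carbon can therefore lower the number well past that of compound 1, as a 3.2-fold lower number from compound 1 to compound 4 (0.50 log units; beyond the scatter) shows, whereas the two earlier changes on the shared core both raised it. The group on the aromatic carbon also matters greatly, with a 170-fold lower number from compound 2 to compound 4 (2.24 log units; beyond the scatter) setting the widest gap in the series, and no measured evidence accounts for any of these steps.

3-cyanophenyl differs from 4-bromophenyl in both the group and its place on the phenyl ring. The compounds shown do not reveal how much of the step belongs to each. They also leave open whether the low number is particular to the nitrile or would hold for an amine or a carboxylic acid on the same aromatic carbon.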